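Swapping nitro for trifluoromethyl on the sulfonyl aryl ring

This account rests on a few compounds, and the source may have more. Where it says the series, first, only, none or still open, it means among the compounds named here.

Measured in a functional assay on HepG2 cells (Homo sapiens) for cytotoxicity, read by MTT assay, with a stated time of 24 h; a lower number here means a stronger inhibitor, a higher number a weaker inhibitor:
Compound 1 `O=C1/C(=C/c2ccncc2)CN(S(=O)(=O)c2ccc(C(F)(F)F)cc2)C/C1=C\c1ccccc1F`: 4030 nM
Compound 2 `O=C1/C(=C/c2cccnc2)CN(S(=O)(=O)c2ccc(C(F)(F)F)cc2)C/C1=C\c1ccccc1C(F)(F)F`: 1710 nM
Compound 3 `O=C1/C(=C/c2ccncc2)CN(S(=O)(=O)c2ccc([N+](=O)[O-])cc2)C/C1=C\c1ccccc1C(F)(F)F`: 13400 nM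

Compound 3 has the highest number of the three, which makes it the weakest inhibitor in this small set, and its gaps to the other two lie beyond the scatter. The next compound, compound 4 `O=C1/C(=C/c2ccncc2)CN(S(=O)(=O)c2ccc(C(F)(F)F)cc2)C/C1=C\c1ccccc1C(F)(F)F`, differs from it in one place: trifluoromethyl in place of nitro on an aromatic carbon. Trifluoromethyl takes the place of nitro on an aromatic carbon, turning 4-nitrophenyl into 4-(trifluoromethyl)phenyl.

Going by the values given here, no measured pair shows this change alone. Still, compound 1 at 4030 nM and compound 2 at 1710 nM both carry 4-(trifluoromethyl)phenyl and both sit lower than compound 3, although each also differs from it elsewhere. A lower number is therefore expected, with the estimated change being a 4.5-fold lower number from compound 3 to compound 4 (0.65 log units; beyond the scatter), a step beyond the scatter. The estimate for compound 4 is 3000 nM, with an expected range from 1200 nM to 8000 nM.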

Compound 4, half-maximal inhibitory concentration: 3240 nM
Compound 4: the middle estimate sits 1.1-fold (0.03 log units) below what was measured, and the stated range covers the measured number.
By their numbers in this assay, from the lowest: compounds 2, 4 and 1 (each within the scatter of the next, the first and the last beyond it); then compound 3.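

In this assay, the first pair differing only at this place gives a 4.1-fold lower number from compound 3 to compound 4 (0.62 log units; beyond the scatter), so with the rest of the molecule unchanged, 4-(trifluoromethyl)phenyl carries a lower number than 4-nitrophenyl. Going by these compounds alone, the other two single changes stay within the scatter: pyridin-4-yl in place of pyridin-3-yl gives a 1.9-fold higher number from compound 2 to compound 4 (0.28 log units; within the scatter), and trifluoromethyl replacing fluoro gives a 1.2-fold lower number from compound 1 to compound 4 (0.09 log units; within the scatter), which leaves the nitro swap as the only single change here with a step beyond the scatter. No measurement shown explains why this swap moves the number.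

The compounds shown leave open how an amine, a methoxy group or a plain hydrogen at this place would compare with nitro and trifluoromethyl. They also leave open whether the swap gives a similar step alongside the pyridin-3-yl of compound 2 or the fluoro of compound 1.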